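The source may hold more compounds than are shown below. What is called first, only, known or untested is meant among the compounds shown, and "the series" means these compounds.

Working notes on the series. Compound 1 `O=C(OC[C@H]1O[C@@H](O[C@@H]2CCCC[C@H]2O)[C@H](O)[C@@H](O)[C@@H]1O)c1ccc(O)cc1` carries the saturated benzoate on the sugar; compound 2 `O=C(/C=C/c1ccc(O)cc1)O[C@H]1[C@H](O[C@H]2CCCC[C@@H]2O)O[C@H](CO)[C@@H](O)[C@@H]1O` and compound 3 `O=C(/C=C\c1ccc(O)cc1)O[C@@H]1[C@H](O[C@H]2CCCC[C@@H]2O)O[C@H](CO)[C@@H](O)[C@H]1O` carry the unsaturated ester instead, on a different hydroxyl of the shared core. In a functional assay on A549 cells (Homo sapiens) for cytotoxicity, read by sulforhodamine B assay (on this read-out higher numbers stand for weaker inhibition and lower numbers for stronger inhibition), compound 1 gives > 10000 nM, which is a limit of the assay and not a number. Compound 2 likewise reaches only the limit > 10000 nM in this assay. Compound 3 also stands at the limit > 10000 nM in this assay. Compound 3 therefore stands where every value shown stands: the limit of > 10000 nM in this assay, at which 3 of the 3 values shown sit. Among the measured compounds shown here, the only step between measured compounds, a step that the two limits leave unreadable from compound 2 to compound 3, cannot be sized because both of its ends are limits; the pair is tied together by the fact that compounds 2 and 3 differ only in the configuration as drawn. Compound 4 `O=C(/C=C\c1ccc(O)cc1)O[C@H]1[C@H](O[C@H]2CCCC[C@H]2O)O[C@H](CO)[C@@H](O)[C@@H]1O` is the next stereoisomer: the two compounds have the same atoms and bonds and differ only in configuration as drawn: 3 of 8 stereo elements differ; a stereocentre at a saturated ring carbon is drawn S in compound 3 and R in compound 4; a stereocentre at a saturated ring carbon is drawn S in compound 3 and R in compound 4; a stereocentre at a saturated ring carbon is drawn R in compound 3 and S in compound 4. For the measured compounds named here, this change is of the same kind as the single measured step, which is the only one that bears on it, and that step gave no readable size. With three of three values at the limit, no movement beyond the scatter is expected in this assay, and compound 4 is expected to remain at the limit as well. The step from compound 3 to compound 4 is expected to be about a step that the limit leaves unreadable from compound 3 to compound 4. For compound 4 the estimate is 20000 nM, with a range from 10000 nM to 100000 nM.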

Compound 4, half-maximal inhibitory concentration: > 10000 nM
Compound 4: no number, only a limit; the forecaster's own chance of this, stated with the estimate: 90%; the middle value does not contradict the limit.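

Compound 4 joins compounds 2 and 3 at the limit in this assay, so no step among these three compounds can be read, all their ends being limits: the limit of > 10000 nM in this assay, at which 4 of the 4 values shown sit.

The compounds shown leave open whether any configuration or ester placement on the shared core changes cytotoxicity in this read-out.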